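The source may report more compounds than this note shows. Statements on the series, on what has been measured and on what is new or still open speak of the compounds shown alone.

Compound 1 `O=C(O)CC/C=C\CC1COC(c2ccccc2Cl)OC1c1cccnc1` gives 759 nM in a functional assay for inhibition, with Homo sapiens as the target; on this read-out higher numbers stand for weaker binding and lower numbers for tighter binding. Compound 2 `O=C(O)CC/C=C\CC1COC(c2cccnc2)OC1c1cccnc1` gives 759 nM in this assay, so compound 1 stands level with compound 2 at the digits shown; the step of no change at the digits printed from compound 1 to compound 2 (within the scatter), pyridin-3-yl in place of 2-chlorophenyl on a saturated ring carbon, lies within the scatter.

Compound 3 `CC(C)(Oc1ccccc1)C1OCC(C/C=C\CCC(=O)O)C(c2cccnc2)O1` is not yet measured. Its change from compound 1 is a group of 10 heavy atoms (9 carbon, 1 oxygen; one six-membered aromatic ring of carbon only) in place of a group of 7 heavy atoms (6 carbon, 1 chlorine; one six-membered aromatic ring of carbon only), on a saturated ring carbon, at the position between two ring oxygen atoms of the shared core. Within the data shown here, the only measured step at this position, from compound 1 to compound 2, swapped one aromatic group for another and produced no change beyond the scatter; the entering group here is larger and carries an oxygen, for which no measured step exists. The step from compound 1 to compound 3 is therefore expected to be a 1.0-fold higher number from compound 1 to compound 3 (0.00 log units; within the scatter), none beyond the scatter, with wide uncertainty. Compound 3 is estimated at 760 nM in this assay, within 250 nM to 2500 nM.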

Compound 3, dissociation constant: 75.9 nM
Beside the measured number, compound 3's estimate is 10-fold (1.00 log units) above it; the whole stated range lies above it.
By their numbers in this assay, from the lowest: compound 3; then compounds 1 and 2 (each within the scatter of the next).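

In this assay, the position between two ring oxygen atoms turns out to respond to the group it carries: the step is a 10-fold lower number from compound 1 to compound 3 (1.00 log units; beyond the scatter), and likewise a 10-fold lower number from compound 2 to compound 3 (1.00 log units; beyond the scatter). The earlier exchange of 2-chlorophenyl for pyridin-3-yl gave no change at the digits printed from compound 1 to compound 2 (within the scatter), so that pair alone showed no response here, while the group of 10 heavy atoms with its oxygen shows that this saturated ring carbon is not indifferent to what it bears. No measurement at hand accounts for the step.

Open, from the compounds shown here alone, is which part of the entering group goes with the lower number, as a phenoxymethyl group or a tert-butyl group in its place would help to separate. Also open, going by these compounds, is whether the step holds with a longer chain in place of the 5-carboxypent-2-en-1-yl group.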